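Methylsulfonyl step from compound 2 to compound 3

The compounds below may be only part of what the source reports. "The series", "measured", "known", "first", "only" and "open" are said of these compounds alone.

Measured in a functional assay on the whole organism with Canis familiaris (Canis lupus familiaris) as the target; on this read-out lower numbers stand for an effect already at smaller amounts and higher numbers for an effect only at larger amounts of compound:
- compound 1 `CS(=O)(=O)c1ccc(-c2nc3cc[nH]cc-3n2)cc1`: 7.5 mg/kg
- compound 2 `CCOc1cc([S+](C)[O-])ccc1-c1nc2cc[nH]cc-2n1`: 0.1 mg/kg

Compound 2 holds the lower of the two numbers at 0.1 mg/kg, and compound 1 stands at 7.5 mg/kg, a gap that lies beyond the scatter. Next in line is compound 3 `CCOc1cc(S(C)(=O)=O)ccc1-c1nc2cc[nH]cc-2n1`, not yet measured. Its structural change is a group of 4 heavy atoms (1 carbon, 2 oxygen, 1 sulfur; no ring) in place of a group of 3 heavy atoms (1 carbon, 1 oxygen, 1 sulfur; no ring), on an aromatic carbon: methylsulfonyl enters on an aromatic carbon, meta to an ethoxy group, and the ethoxy group stays. Among the measured compounds shown here, no measured step guides the size of this change. Compound 1 at 7.5 mg/kg also carries methylsulfonyl but has no ethoxy group, so a modest rise in this assay is expected rather than a return to that level. The expected change is a 3.0-fold higher number from compound 2 to compound 3 (0.48 log units; beyond the scatter). For compound 3 the estimated value is 0.3 mg/kg, with an expected range of 0.08 mg/kg to 1.5 mg/kg.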

Compound 3, dose for half-maximal effect: 0.07 mg/kg
For compound 3 the middle estimate is 4.3-fold (0.63 log units) above the measured one, outside the stated range (below it).
By their numbers in this assay, from the lowest: compounds 3 and 2 (each within the scatter of the next); then compound 1.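

With the ethoxy group kept, methylsulfonyl on the aromatic carbon meta to that ethoxy group gives a 1.4-fold lower number from compound 2 to compound 3 (0.15 log units; within the scatter) in this assay and so cannot be told apart from the group it replaces on this read-out. Among the compounds shown here, with methylsulfonyl kept, ethoxy in place of hydrogen on an aromatic carbon gives a 110-fold lower number from compound 1 to compound 3 (2.03 log units; beyond the scatter) and this is the first single-place comparison to isolate a large step, showing that methylsulfonyl alone does not set the level here. No supporting data bear on the reason for either step.

The compounds shown leave open whether methoxy or a longer chain such as propoxy in place of ethoxy would keep this level. They also leave open whether an amine or a carboxylic acid in place of methylsulfonyl would be tolerated at this position.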